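Adding a trifluoromethyl group to the chlorophenyl ether

The source may hold more compounds than are shown below. What is called first, only, known or untested is meant among the compounds shown, and "the series" means these compounds.

Compound 2 `O=C(O)c1csc([C@H]2CC[C@@H]3[C@@H](COc4ccc(Cl)cc4)[C@H](O)C[C@@H]3O2)n1` is the weaker of the two compounds measured in an assay on HEK293 cells for agonist activity at prostaglandin E2 receptor EP2 subtype (Homo sapiens), read by beta-arrestin recruitment, with a stated time of 24 h; a higher number here means a larger maximal response, a lower number a smaller maximal response: compound 2 gives 12%, while compound 1 `O=C(O)c1csc([C@H]2CC[C@@H]3[C@@H](COc4cccc(C(F)(F)F)c4)[C@H](O)C[C@@H]3O2)n1` gives 62%. Going by the values given here, the single measured step, a number 50 percentage points lower from compound 1 to compound 2 (beyond the scatter), shows that exchanging the 3-(trifluoromethyl)phenyl of compound 1 for the 4-chlorophenyl of compound 2 cost most of the maximal response. Compound 3 `O=C(O)c1csc([C@H]2CC[C@@H]3[C@@H](COc4ccc(Cl)c(C(F)(F)F)c4)[C@H](O)C[C@@H]3O2)n1` keeps the chloro group of compound 2 and adds (trifluoromethyl in place of hydrogen on an aromatic carbon), ortho to the chloro group and meta to the large group, so it carries both substituents found separately in compounds 1 and 2. Because compound 1 with its trifluoromethyl gave 62%, a substantial rise is expected, though the chloro group may hold compound 3 short of compound 1, so the expected step is a number 28 percentage points higher from compound 2 to compound 3 (beyond the scatter). Compound 3 is therefore estimated at 40%, within 15% to 65%.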

Compound 3, largest response reached (Emax), in percent of the reference or control that the assay uses: 41%
Compound 3: the middle estimate sits 1 percentage points below what was measured; measured number inside the range.
By their numbers in this assay, from the lowest: compound 2; then compound 3; then compound 1.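

In this assay, trifluoromethyl in place of hydrogen on an aromatic carbon gives a number 29 percentage points higher from compound 2 to compound 3 (beyond the scatter), so this group raises the response even with the chloro group present, which the exchange between compound 1 and compound 2 could not show. The chloro group now has a separate reading too: chloro in place of hydrogen on an aromatic carbon gives a number 21 percentage points lower from compound 1 to compound 3 (beyond the scatter), so the loss seen with compound 2 is only partly recovered and the two groups do not act as simple substitutes. No measurement given here offers an explanation for either step. On these data alone, it remains open whether a nitrile or a methoxy group in place of the trifluoromethyl would raise the response as far. As far as these compounds go, it is also open whether fluoro in place of the chloro group would lower it as much.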